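A few compounds are considered here, and "the series" means these few. Any claim that something is new, unique, unknown or untested is made for them only; others in the source may bear on it.

Measured so far:
compound 1 `CC(C)c1n[nH]c2c(NCc3ccc(-c4ccccn4)cc3)nc(SCC(O)C(F)(F)F)nc12`, 690 nM;
compound 2 `CC(C)c1n[nH]c2c(NCc3ccc(-c4ccccn4)cc3)nc(SCCC(N)=O)nc12`, 120 nM;
compound 3 `CC(C)c1n[nH]c2c(NCc3ccc(-c4ccccn4)cc3)nc(SCC(O)CN)nc12`, 55 nM.

In a functional assay on HT cells (Homo sapiens) for antiproliferative activity, read by fluorescence, with a stated time of 72 h (on this read-out higher numbers stand for weaker inhibition of growth and lower numbers for stronger inhibition of growth), compound 3 stands lowest of the three, with a 2.2-fold lower number from compound 2 to compound 3 (0.34 log units; beyond the scatter) and a 13-fold lower number from compound 1 to compound 3 (1.10 log units; beyond the scatter) both beyond the scatter. Compound 4 `CC(C)c1n[nH]c2c(NCc3ccc(-c4ccccn4)cc3)nc(SCCNC(=N)N)nc12` differs from compound 3 by a group of 5 heavy atoms (2 carbon, 3 nitrogen; no ring) in place of a group of 4 heavy atoms (2 carbon, 1 nitrogen, 1 oxygen; no ring), on a saturated chain carbon bound to a sulfur. All three measured steps sit on the same saturated chain carbon bound to a sulfur, and the two that brought in a nitrogen there, a 5.8-fold lower number from compound 1 to compound 2 (0.76 log units; beyond the scatter) and a 13-fold lower number from compound 1 to compound 3 (1.10 log units; beyond the scatter), lowered the number. Compound 4 keeps nitrogen on that chain, so a step no larger than the scatter is expected in this assay, giving an estimated 1.3-fold higher number from compound 3 to compound 4 (0.10 log units; within the scatter). Compound 4 is thus expected to give about 70 nM, between 25 nM and 200 nM.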

Compound 4, concentration for 50% growth inhibition: 390 nM
Estimate against measurement, compound 4: 5.6-fold (0.75 log units) below; measured number above the stated range.
By their numbers in this assay, from the lowest: compound 3; then compound 2; then compounds 4 and 1 (each within the scatter of the next).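

The group of 5 heavy atoms gives a 7.1-fold higher number from compound 3 to compound 4 (0.85 log units; beyond the scatter) and a 3.3-fold higher number from compound 2 to compound 4 (0.51 log units; beyond the scatter) on the same chain, so nitrogen there does not by itself lower the number. The compound with no nitrogen on this chain is not separated from the new one, as a 1.8-fold lower number from compound 1 to compound 4 (0.25 log units; within the scatter) shows, so which nitrogen group sits there counts, not merely its presence. Nothing measured here gives a reason for this. Still open, as far as these compounds go, is how a plain amine without the hydroxyl, or a carboxylic acid, would compare on this chain. Also open, from the compounds shown here alone, is whether a longer chain would change the result for the group in compound 4.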